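This account rests on a few compounds, and the source may have more. Where it says the series, first, only, none or still open, it means among the compounds named here.

Compound 1 `Cc1ccc(-c2nc(=O)o[nH]2)c(-c2ccc([C@@H](C)N(CC3CC3)c3nc4c(C(=O)O)cccc4o3)cc2)c1` in an ADME assay on the whole organism (Macaca fascicularis) for metabolic stability, read by LC-MS, using cassette dosing, at a dose of 1 mg/kg by the oral route (a higher number here means that the compound lasts longer, a lower number that the compound disappears faster), gives 2.8 h, the lowest of the three numbers shown, though compound 2 `CCCCN(c1nc2c(C(=O)N(C)C)cccc2o1)[C@H](C)c1ccc(-c2ccccc2-c2nnn[nH]2)cc1` with 3.2 h and compound 3 `CCCCN(c1nc2c(C(=O)O)cccc2o1)[C@H](C)c1ccc(-c2ccccc2-c2nnn[nH]2)cc1` with 3.7 h both sit within the scatter of it. Going by the values given here, the only measured step in the set, a 1.2-fold higher number from compound 2 to compound 3 (0.06 log units; within the scatter), concerns the group on the carbonyl carbon and not the aromatic position now in question. Compound 4 `C[C@H](c1ccc(-c2ccccc2-c2nc(=O)o[nH]2)cc1)N(CC1CC1)c1nc2c(C(=O)O)cccc2o1` differs from compound 1 by hydrogen in place of methyl on an aromatic carbon. Among the compounds with values here, no measured step bears directly on this change; a single carbon removed from an aromatic carbon gives no ground to expect a move beyond the scatter in this assay. Compound 4 is therefore expected at about 2.8 h, range 1.6 h to 4.8 h, meaning an estimated no change at the digits printed from compound 1 to compound 4 (within the scatter).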

Compound 4, half-life: 2.6 h
Compound 4: middle estimate off by 1.1-fold (0.03 log units), on the high side, and the stated range covers the measured number.
By their numbers in this assay, from the lowest: compounds 4, 1, 2 and 3 (each within the scatter of the next).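

In this assay, going by these compounds alone, the first reading at this position, hydrogen in place of methyl on an aromatic carbon meta to a large group and para to a group of 6 heavy atoms, is a 1.1-fold lower number from compound 1 to compound 4 (0.03 log units; within the scatter) and lies within the scatter. The half-life of this series therefore holds without the methyl, at least with the rest of compound 1 unchanged. Nothing available explains this result.

On these data alone, whether a larger group on this aromatic carbon, such as methoxy, chlorine or an amine, would move the half-life beyond the scatter remains open.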